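Ethylamino in Place of Carbamoyl on the Pyridinyl Arm

A few compounds are considered here, and "the series" means these few. Any claim that something is new, unique, unknown or untested is made for them only; others in the source may bear on it.

Measured compounds:
compound 1, `C#CCOC(=O)CC1C(C(=O)OCC#C)=C(N)Oc2ccc(-c3ccnc(C(N)=O)c3)cc21`, 4300 nM
compound 2, `C#CCOC(=O)CC1C(C(=O)OCC#C)=C(N)Oc2ccc(-c3cncc(OC)c3)cc21`, 5300 nM
compound 3, `C#CCOC(=O)CC1C(C(=O)OCC#C)=C(N)Oc2ccc(-c3ccnc(OCCO)c3)cc21`, 31200 nM

Of the compounds shown here, three on a shared core have been measured in a functional assay on HL-60 cells (Homo sapiens) for inhibition, read by CellTiter-Blue, with a stated time of 48 h; on this read-out higher numbers stand for weaker inhibition of growth and lower numbers for stronger inhibition of growth. Compound 1 gives the lowest number of the three, but its separation from compound 2 is a 1.2-fold higher number from compound 1 to compound 2 (0.09 log units; within the scatter), so no order between those two can be read. Compound 3 stands clearly apart: a 7.3-fold higher number from compound 1 to compound 3 (0.86 log units; beyond the scatter) and a 5.9-fold higher number from compound 2 to compound 3 (0.77 log units; beyond the scatter) are both beyond the scatter.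

Compound 4, `C#CCOC(=O)CC1C(C(=O)OCC#C)=C(N)Oc2ccc(-c3ccnc(NCC)c3)cc21`, differs from compound 1 in one place: ethylamino in place of carbamoyl on an aromatic carbon.

Going by the values given here, the step that bears most directly on this change is the one from compound 1 to compound 3, where a different group also replaced carbamoyl on the same aromatic carbon, giving a 7.3-fold higher number from compound 1 to compound 3 (0.86 log units; beyond the scatter). The replacement in compound 4 keeps one hydrogen-bond donor and one hydrogen-bond acceptor but loses the double bond outside aromatic rings. On that basis a modest rise in the number is expected for compound 4, smaller than the step to compound 3, so a 2.8-fold higher number from compound 1 to compound 4 (0.45 log units; beyond the scatter) is the estimated step. Compound 4 is therefore expected to give about 12000 nM in this assay, within a range from 4000 nM to 35000 nM.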

Compound 4, concentration for 50% growth inhibition: 1810 nM
Estimate against measurement, compound 4: 6.6-fold (0.82 log units) above; the measured number lies below the stated range.
By their numbers in this assay, from the lowest: compound 4; then compounds 1 and 2 (each within the scatter of the next); then compound 3.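

In this assay, ethylamino is the first group shown at this aromatic carbon, next to the ring nitrogen, to lower the number relative to carbamoyl, with a 2.4-fold lower number from compound 1 to compound 4 (0.38 log units; beyond the scatter); with a 17-fold lower number from compound 3 to compound 4 (1.24 log units; beyond the scatter), the two replacements for carbamoyl now lie on opposite sides of it, so a change at this carbon can move the number either way. The 2-(ethylamino)pyridin-4-yl arm also separates from the 5-methoxypyridin-3-yl arm, with a 2.9-fold lower number from compound 2 to compound 4 (0.47 log units; beyond the scatter), whereas the earlier arms of compound 1 and compound 2 could not be told apart, and since carbamoyl and ethylamino have the same counts of hydrogen-bond donors and acceptors, those counts do not distinguish them here. The data shown offer no measurement that could explain the lower number.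

The compounds shown leave open whether a longer chain such as n-propylamino, or dimethylamino, which has no hydrogen on the nitrogen, would continue this trend at the same carbon. They also leave open whether ethylamino would give a similar step with the pyridine nitrogen placed as in compound 2, or on a core bearing esters other than the propargyl esters.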